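A few compounds are considered here, and "the series" means these few. Any claim that something is new, unique, unknown or untested is made for them only; others in the source may bear on it.

In a functional assay on BT-549 cells (Homo sapiens) for inhibition, with a stated time of 48 h (a lower number here means a stronger inhibitor of growth, a higher number a weaker inhibitor of growth), compound 1 (`COc1ccccc1/C=C/C(=O)c1c(O)cc2occc2c1OC`) gives 28200 nM, while compound 2 (`C=CCc1c(O)c(C(=O)/C=C/c2ccccc2)c(OC)c2ccoc12`) gives 2630 nM. Compound 2 therefore holds the lower of the two numbers, and the gap between them lies beyond the usual scatter. Compound 3 (`C=CCc1c(O)c(C(=O)/C=C/c2ccc(Cl)cc2)c(OC)c2ccoc12`) has not yet been measured. It carries chloro in place of hydrogen on an aromatic carbon of compound 2, para to a large group (chloro in place of hydrogen on an aromatic carbon). Within the data shown here, no measured pair shows this change, so the expectation is tentative. The expected step in this assay is a modest one toward a lower number, a 1.4-fold lower number from compound 2 to compound 3 (0.14 log units; within the scatter). The estimate for compound 3 is 1900 nM, with an expected range from 700 nM to 5000 nM.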

Compound 3, concentration for 50% growth inhibition: 3000 nM
Compound 3: the middle estimate sits 1.6-fold (0.20 log units) below what was measured; measured number inside the range.
By their numbers in this assay, from the lowest: compounds 2 and 3 (each within the scatter of the next); then compound 1.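

Among these compounds, the first single-place step in this assay is phenyl to 4-chlorophenyl, and it reads a 1.1-fold higher number from compound 2 to compound 3 (0.06 log units; within the scatter). At this place, para to a large group, chloro in place of hydrogen therefore gives no difference that can be told from the scatter. No measurement here offers an account of this result. Going by these compounds, whether an amine or a carboxylic acid at the same place would separate from compound 2 remains open. So does whether chloro elsewhere on this ring would behave as it does here.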